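Isopropyl(methyl)sulfamoyl in place of amino on the ester

This account rests on a few compounds, and the source may have more. Where it says the series, first, only, none or still open, it means among the compounds named here.

In a functional assay on the whole organism (strain Sprague-Dawley) for inhibition, with Rattus norvegicus as the target, with a stated time of 10 min (a lower number here means that less compound is needed, a higher number that more compound is needed for the effect), compound 1 (`CCOc1ccccc1-c1ncc(C(=O)O)c(=O)[nH]1`) gives 0.5 mg/kg and compound 2 (`CCOc1ccc(N)cc1-c1ncc(C(=O)O)c(=O)[nH]1`) gives 1.2 mg/kg while compound 3 (`CCOC(=O)c1cnc(-c2cc(N)ccc2OCC)[nH]c1=O`) gives 0.5 mg/kg and so stands level with compound 1, together the lowest of the three numbers. Compound 4 (`CCOC(=O)c1cnc(-c2cc(S(=O)(=O)N(C)C(C)C)ccc2OCC)[nH]c1=O`) carries isopropyl(methyl)sulfamoyl in place of amino on an aromatic carbon. Among the compounds with values here, two measured steps bear on this only loosely, both modest: amino in place of hydrogen (a 2.4-fold higher number from compound 1 to compound 2 (0.38 log units; beyond the scatter)) and ethyl in place of hydrogen (a 2.4-fold lower number from compound 2 to compound 3 (0.38 log units; beyond the scatter)). Within the data shown here, no measured compound carries a sulfamoyl group, so either direction stays open in this assay and a modest rise of similar size is expected. The expected change is a 2.4-fold higher number from compound 3 to compound 4 (0.38 log units; beyond the scatter) as estimated here. The estimate for compound 4 is 1.2 mg/kg with an expected range from 0.25 mg/kg to 5 mg/kg in this series.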

Compound 4, dose for 50% inhibition: > 10 mg/kg
Compound 4: a limit, no number; the forecaster's own chance of this, stated with the estimate: 5%; middle value at least 8.3-fold (0.92 log units) from the limit.
By their numbers in this assay, from the lowest: compounds 1 and 3 (each within the scatter of the next); then compound 2. At a limit, above all of these: compound 4.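

Isopropyl(methyl)sulfamoyl in place of amino, on the aromatic carbon para to an ethoxy group, gives the first large step in the series in this assay: an at least 20-fold higher number from compound 3 to compound 4 (1.30 log units; beyond the scatter). At this position the earlier change, amino in place of hydrogen, gave only a 2.4-fold higher number from compound 1 to compound 2 (0.38 log units; beyond the scatter), so the position is not indifferent to what it carries. Compound 4 stands at a limit, not a number: the limit of > 10 mg/kg in this assay, at which 1 of the 4 values shown sits.

Going by these compounds, the size of the step beyond that limit stays open. So does whether a plain sulfamoyl or a methylsulfonyl group would stay close to compound 3 at 0.5 mg/kg.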